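Aryl variation on a shared core: antiproliferative notes

A few compounds are considered here, and "the series" means these few. Any claim that something is new, unique, unknown or untested is made for them only; others in the source may bear on it.

Measured so far:
compound 1 `C/C(=C\CC/C(C)=C/CC[C@@H]1[C@@]2(C)CCC(=O)C(C)(C)[C@H]2CC[C@@]1(C)O)CC/C=C(\C)C(=O)OCc1cn(-c2ccc(F)cc2)nn1`: in a functional assay on DU-145 cells (Homo sapiens) for antiproliferative activity, read by MTT assay, with a stated time of 48 h (a lower number here means a stronger inhibitor, a higher number a weaker inhibitor), compound 1 gives only a limit, > 150000 nM.
compound 2 `C/C(=C\CC/C(C)=C/CC[C@@H]1[C@@]2(C)CCC(=O)C(C)(C)[C@H]2CC[C@@]1(C)O)CC/C=C(\C)C(=O)OCc1cn(-c2ccc([N+](=O)[O-])cc2)nn1`: in this assay compound 2 gives only a limit, > 150000 nM.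
compound 3 `C/C(=C\CC/C(C)=C/CC[C@@H]1[C@@]2(C)CCC(=O)C(C)(C)[C@H]2CC[C@@]1(C)O)CC/C=C(\C)C(=O)OCc1cn(-c2ccc(Cl)cc2)nn1`: in this assay compound 3 gives only a limit, > 150000 nM.

Compound 1 therefore stands nowhere readable on the numbers shown: its value is a limit of this assay, not a number, and the same holds for the other two, as the limit of > 150000 nM in this assay, at which 3 of the 3 values shown sit, records. The steps from it are unreadable for the same reason: a step that the two limits leave unreadable from compound 1 to compound 2 and a step that the two limits leave unreadable from compound 1 to compound 3, and likewise a step that the two limits leave unreadable from compound 2 to compound 3.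

The unmeasured compound 4 `C/C(=C\CC/C(C)=C/CC[C@@H]1[C@@]2(C)CCC(=O)C(C)(C)[C@H]2CC[C@@]1(C)O)CC/C=C(\C)C(=O)OCc1cn(-c2cccc(C(F)(F)F)c2)nn1` differs from compound 1 as follows: 3-(trifluoromethyl)phenyl in place of 4-fluorophenyl on an aromatic nitrogen. Within the data shown here, no measured step in this assay gives a readable size, so no direction can be drawn; what the three values share is the limit noted in the limit of > 150000 nM in this assay, at which 3 of the 3 values shown sit. The expectation is that compound 4 also returns a limit rather than a number, with an estimated step that the limit leaves unreadable from compound 1 to compound 4. Compound 4 is thus estimated at 200000 nM, in a range from 50000 nM to 1000000 nM.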

Compound 4, half-maximal inhibitory concentration: > 150000 nM
Compound 4 gave a limit, no number; the forecaster's own chance of this, stated with the estimate: 85%; the middle value is on the limit's open side.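

No step between compound 4 and compound 1, compound 2 or compound 3 can be read, since all four give a limit, not a number, in this assay: the limit of > 150000 nM in this assay, at which 4 of the 4 values shown sit.

The compounds shown leave open whether any aryl group on the shared core gives a readable value in this assay, and how far these four compounds differ.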